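Swapping one benzyl group at the assay limit

The source may report more compounds than this note shows. Statements on the series, on what has been measured and on what is new or still open speak of the compounds shown alone.

Compound 1 `COc1cc(OC)c(-c2coc3cc(OCc4ccc([N+](=O)[O-])cc4)ccc3c2=O)cc1OC`: > 10000 nM, a limit
Compound 2 `COc1cc(OC)c(-c2coc3cc(OCc4ccccc4C(F)(F)F)ccc3c2=O)cc1OC`: > 10000 nM, a limit

Both entries come from a functional assay on A-375 cells (Homo sapiens) for antiproliferative activity, read by MTT assay, with a stated time of 24 h; on this read-out higher numbers stand for weaker inhibition and lower numbers for stronger inhibition. In this assay compound 2 gives > 10000 nM, which is a limit and not a number. The same limit holds for both compounds: the limit of > 10000 nM in this assay, at which 2 of the 2 values shown sit.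

Compound 3 `COc1cc(OC)c(-c2coc3cc(OCc4ccc(C#N)cc4)ccc3c2=O)cc1OC` carries 4-cyanophenyl in place of 2-(trifluoromethyl)phenyl on a saturated chain carbon bound to an oxygen on an aromatic ring.

Among the compounds with values here, only one measured change bears on this place, a step that the two limits leave unreadable from compound 1 to compound 2, so it offers no size to carry over. The limits of compound 1 at > 10000 nM and compound 2 give no sign of activity, so no step beyond the scatter is expected in this assay, and no direction can be named. The expected step is a step that the limit leaves unreadable from compound 2 to compound 3. For compound 3 the estimate is 15000 nM, with an expected range of 6000 nM to 40000 nM.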

Compound 3, half-maximal inhibitory concentration: 1550 nM
Compound 3: the middle estimate sits 9.7-fold (0.99 log units) above what was measured; the whole stated range lies above it.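

In this assay, this position turns out to allow measurable activity: 4-cyanophenyl in place of 2-(trifluoromethyl)phenyl gives an at least 6.4-fold lower number from compound 2 to compound 3 (0.80 log units; beyond the scatter), and cyano in place of nitro on an aromatic carbon gives an at least 6.4-fold lower number from compound 1 to compound 3 (0.80 log units; beyond the scatter). The step from compound 1 to compound 2 still cannot be read, so those two groups cannot be ranked. Only compound 3 gives a number rather than a limit: the limit of > 10000 nM in this assay, at which 2 of the 3 values shown sit.

On these data alone, whether an amine or a carboxylic acid in place of the cyano would keep this activity stays open.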